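Branching the Ester Chain: From Compound 3 to Compound 4

This account rests on a few compounds, and the source may have more. Where it says the series, first, only, none or still open, it means among the compounds named here.

Measured compounds:
compound 1 `CC1=C(C(=O)OCC(C)C)C(c2ccco2)NC(=O)N1C`: 13%
compound 2 `COC(=O)C1=C(C)N(C)C(=O)NC1c1ccoc1`: 15%
compound 3 `CCCOC(=O)C1=C(C)N(C)C(=O)NC1c1ccoc1`: 1%

In an assay on membranes from CHO cells for displacement of a labelled ligand from adenosine receptor A1 (Homo sapiens), read by scintillation counting, with a stated time of 60 min, tested at 1 uM (on this read-out higher numbers stand for more inhibition at the one concentration tested (going by the name of the read-out) and lower numbers for less inhibition), compound 3 gives the lowest of the three numbers; compound 1 and compound 2 both lie above it, each gap beyond the scatter. Compound 4 `CC1=C(C(=O)OCC(C)C)C(c2ccoc2)NC(=O)N1C` differs from compound 3 by methyl in place of hydrogen on a saturated chain carbon bound to two saturated chain carbons. Within the data shown here, no measured step concerns this kind of branching. Among the measured compounds shown here, the only step available, a number 14 percentage points lower from compound 2 to compound 3 (beyond the scatter), shows that lengthening the ester chain by an ethyl lowered the read-out modestly; it does not say how a further methyl at the branch point behaves. Compound 1 carries the same isobutyl ester as compound 4 but differs elsewhere; in this assay compound 1 gives 13%, somewhat above compound 3. Compound 4 is therefore expected to move by a number 5 percentage points higher from compound 3 to compound 4 (within the scatter), a change within the scatter and of no clear direction. Compound 4 is estimated at 6%, in a range from 0% to 18%.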

Compound 4, a percentage reported as inhibition, at one concentration (the size of the read-out at that concentration, not a potency): 4%
The estimate for compound 4 lay 2 percentage points above the measured number, within the range that was stated.
By their numbers in this assay, from the lowest: compounds 3, 4, 1 and 2 (each within the scatter of the next, the first and the last beyond it).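

In this assay, the change from propyl to isobutyl gives a number 3 percentage points higher from compound 3 to compound 4 (within the scatter) and so shows no measurable effect of this branch on the ester chain. The branched chain, like the straight one, stays under the methyl ester, with a number 11 percentage points lower from compound 2 to compound 4 (beyond the scatter) standing beside the earlier a number 14 percentage points lower from compound 2 to compound 3 (beyond the scatter) as a second modest step in the same direction. With the isobutyl ester held constant, furan-3-yl in place of furan-2-yl on the saturated ring carbon gives a number 9 percentage points lower from compound 1 to compound 4 (within the scatter) and so shows no clear effect of that exchange.

The compounds shown leave open how an amine or a carboxylic acid at the end of the ester chain would read, and whether a longer chain would fall further. They also leave open a phenyl ring in place of the furan, and no evidence speaks to what lies behind these numbers.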